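Amide variation on the shared diazabicyclic core

A few compounds are considered here, and "the series" means these few. Any claim that something is new, unique, unknown or untested is made for them only; others in the source may bear on it.

Three amides of the shared core have a number in an assay on SH-EP1 cells for agonist activity at Neuronal acetylcholine receptor; alpha4/beta2 (Homo sapiens), read by FLIPR and calcium flux; a lower number here means that less compound is needed, a higher number that more compound is needed for the effect. Compound 1 `CCCC(=O)N1CC2CC(C1)N2` carries a propyl group on the carbonyl carbon and in this assay gives 580 nM, the lowest of the three. Compound 2 `O=C(C1CCCC1)N1CC2CC(C1)N2` carries a cyclopentyl group and in this assay gives 11000 nM. Compound 3 `O=C(C1CC=CC1)N1CC2CC(C1)N2` carries a cyclopentenyl group and in this assay gives 6600 nM. Both ring-bearing compounds stand beyond the scatter from compound 1, compound 2 the furthest, compound 3 nearer.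

Compound 4 `O=C([C@@H]1C[C@@H]1F)N1CC2CC(C1)N2` is not yet measured. It differs from compound 1 in one place: 2-fluorocyclopropyl in place of propyl on a carbonyl carbon. Within the data shown here, the only comparison available, compound 1 against compound 2 and compound 3, shows that a ring on the carbonyl carbon has so far gone with higher numbers than the open chain, though the ring entering in compound 4 is smaller than either ring measured.

For compound 4 the expected step in this assay from compound 1 is a 2.6-fold higher number from compound 1 to compound 4 (0.41 log units; beyond the scatter), towards a higher number but not as far as compound 2 or compound 3. The estimate for compound 4 in this assay is 1500 nM, with a range from 400 nM to 6000 nM.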

Compound 4, half-maximal effective concentration: 120 nM
Compound 4: middle estimate off by 13-fold (1.10 log units), on the high side; measured number outside the range, below it.
By their numbers in this assay, from the lowest: compound 4; then compound 1; then compounds 3 and 2 (each within the scatter of the next).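

In this assay the change on the carbonyl carbon gives a 4.8-fold lower number from compound 1 to compound 4 (0.68 log units; beyond the scatter), so this position can carry a ring and still give a lower number than the open propyl chain. A ring here therefore does not go with higher numbers across the series: compound 2 and compound 3 fit that earlier reading, while compound 4 goes against it. No measurement at hand accounts for this step.

The ring and the fluorine enter together, so the shown compounds do not separate their shares in the step; plain cyclopropyl on the same carbonyl carbon would address this. Also open is how the other stereoisomers of 2-fluorocyclopropyl, or a cyclobutyl group, which is a ring size between those shown, would read in this assay.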